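Indolylmethyl in Place of Phenyl on the Ring Nitrogen

The compounds below may be only part of what the source reports. "The series", "measured", "known", "first", "only" and "open" are said of these compounds alone.

Measured compounds and their values:
Compound 1, `COc1ccc2[nH]c(C(=O)N3CC(=O)N(Cc4cccc(OC)n4)[C@@H](Cc4ccccc4)C3)cc2c1`, gives 47500 nM in a physicochemical assay for solubility, read by spectrophotometry, in phosphate buffer, with a stated time of 2 h, at pH 7.4; a higher number here means a more soluble compound, a lower number a less soluble compound.
Compound 2, `COc1ccc2[nH]c(C(=O)N3CC(=O)N(Cc4ccc[nH]4)[C@@H](Cc4ccccc4)C3)cc2c1`, gives 38400 nM.
Compound 3, `COc1ccc2[nH]c(C(=O)N3CC(=O)N(c4ccccc4)[C@@H](Cc4ccccc4)C3)cc2c1`, gives 36100 nM.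

Compound 3 holds the lowest of the three numbers, but the gaps to its neighbours are small: a 1.3-fold lower number from compound 1 to compound 3 (0.12 log units; within the scatter) and a 1.1-fold lower number from compound 2 to compound 3 (0.03 log units; within the scatter), both within the scatter, so the three compounds cannot be ordered on these numbers.

Compound 4, `COc1ccc2[nH]c(C(=O)N3CC(=O)N(Cc4c[nH]c5ccccc45)[C@@H](Cc4ccccc4)C3)cc2c1`, has not yet been measured in this assay. It differs from compound 3 in one place: (1H-indol-3-yl)methyl in place of phenyl on an amide-type nitrogen in a ring. The two measured steps that touch the same position, a 1.3-fold lower number from compound 1 to compound 3 (0.12 log units; within the scatter) and a 1.1-fold lower number from compound 2 to compound 3 (0.03 log units; within the scatter), exchanged phenyl for a methylene-linked heteroaryl group and stayed within the scatter in both cases. Among the measured compounds shown here, the entering group is larger than any group seen at this position among the measured compounds, and no measured step covers that kind of growth, so the evidence is indirect.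

On this basis compound 4 is expected to stay close to compound 3, with a step of a 1.3-fold lower number from compound 3 to compound 4 (0.11 log units; within the scatter) that is within the scatter, and its estimated value is 28000 nM, within a range from 11000 nM to 60000 nM.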

Compound 4, solubility: 10300 nM
Compound 4: middle estimate off by 2.7-fold (0.43 log units), on the high side; measured number below the stated range.
By their numbers in this assay, from the lowest: compound 4; then compounds 3, 2 and 1 (each within the scatter of the next).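

In this assay, among the compounds shown here, phenyl, (1H-pyrrol-2-yl)methyl and (6-methoxypyridin-2-yl)methyl on the amide-type nitrogen in a ring had given numbers within the scatter of one another, so this position had looked indifferent to the exchange of one such group for another. (1H-indol-3-yl)methyl ends that picture, with a 3.5-fold lower number from compound 3 to compound 4 (0.54 log units; beyond the scatter), and it is the first group here to give a step beyond the scatter. The same holds where the methylene link is kept and only the ring on it changes, with a 3.7-fold lower number from compound 2 to compound 4 (0.57 log units; beyond the scatter) and a 4.6-fold lower number from compound 1 to compound 4 (0.66 log units; beyond the scatter), so the position does respond to the group it carries, although nothing in the data given explains the lower number.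

The compounds shown leave open which part of the entering group goes with the lower number, its second ring or its ring nitrogen, a question that a naphthalen-1-ylmethyl group, with carbon rings only, would address. They also leave open how a longer chain, such as 2-(1H-indol-3-yl)ethyl, or an aminoethyl group on the same nitrogen would read in this assay.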